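The compounds below may be only part of what the source reports. "The series", "measured", "known", "first", "only" and "open" are said of these compounds alone.

Measured in a functional assay on SK-OV-3 cells (Homo sapiens) for cytotoxicity, read by sulforhodamine B assay; a higher number here means a weaker inhibitor, a lower number a stronger inhibitor:

- Compound 1 `COc1ccc2c(c1)CCCN2c1nc(C)nc2ccccc12` gives 1.5 nM
- Compound 2 `CSc1ccc(N(C)c2nc(C)nc3ccccc23)cc1` gives 1.6 nM
- Compound 3 `COc1ccc(N(C)c2ncnc3ccccc23)cc1` gives 10.4 nM

Compound 1 sits at the low end of these numbers, level with compound 2 within the scatter, while compound 3 lies clearly higher. Compound 4 `COc1ccc2c(c1)CCCN2c1ncnc2ccccc12` keeps the core of compound 1 with one change: hydrogen in place of methyl on an aromatic carbon, between two ring nitrogen atoms (hydrogen in place of methyl on an aromatic carbon). Among the compounds with values here, no measured pair shows this change alone. Compound 3 also carries hydrogen on that carbon and gives 10.4 nM in this assay, but it differs from compound 1 elsewhere too, so it is only a loose guide. A moderate rise, meaning a weaker inhibitor, is expected, with an estimated size of a 5.3-fold higher number from compound 1 to compound 4 (0.73 log units; beyond the scatter) for this step. The estimate for compound 4 is 8 nM (expected range 2.5 nM to 25 nM).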

Compound 4, half-maximal inhibitory concentration: 18.1 nM
Estimate against measurement, compound 4: 2.3-fold (0.35 log units) below; the range from low to high includes it.
By their numbers in this assay, from the lowest: compounds 1 and 2 (each within the scatter of the next); then compounds 3 and 4 (each within the scatter of the next).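

Within the data shown here, this is the first reading of this change on its own: with the rest of compound 1 kept, hydrogen in place of methyl on the aromatic carbon between two ring nitrogen atoms gives a 12-fold higher number from compound 1 to compound 4 (1.08 log units; beyond the scatter) in this assay. Losing that one carbon atom therefore costs much of the potency in this pair. Nothing available explains why the step is so large.

As far as these compounds go, whether an ethyl group or an amine on this carbon would keep the potency of compound 1 remains open. So does whether the same step would appear with other groups elsewhere on the core.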